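Chloro in Place of Acetyl on Compound 2

The source may report more compounds than this note shows. Statements on the series, on what has been measured and on what is new or still open speak of the compounds shown alone.

In a functional assay on MCF7 cells (Homo sapiens) for cytotoxicity, read by MTT assay, with a stated time of 48 h (on this read-out higher numbers stand for weaker inhibition and lower numbers for stronger inhibition), compound 1 (`C#CC1=CC[C@]2(CC1)C(=C)CC[C@H]2C(C)C`) gives 135000 nM and compound 2 (`C=C1CCC[C@]2(C)CCC(c3cn(-c4ccc(C(C)=O)cc4)nn3)=CC[C@@]12C`) gives 65400 nM while compound 3 (`C=C1CCC[C@]2(C)CCC(c3cn(CC(=O)Nc4ccc(C)cc4)nn3)=CC[C@@]12C`) gives 80100 nM as its number. Compound 2 and compound 3 lie within the scatter of each other, and compound 1 has a higher number than compound 2, beyond the scatter. Compound 4 (`C=C1CCC[C@]2(C)CCC(c3cn(-c4ccc(Cl)cc4)nn3)=CC[C@@]12C`) differs from compound 2 in one place: chloro in place of acetyl on an aromatic carbon, para to a large group. For the measured compounds named here, no measured pair shows this change alone. Compound 2 (65400 nM) and compound 3 (80100 nM) carry different side groups yet stay within the scatter, so no step beyond the scatter is expected in this assay here. The estimated step (a 1.1-fold lower number from compound 2 to compound 4 (0.04 log units; within the scatter)) is small. Compound 4 is expected at 60000 nM (estimated range from 28000 nM to 125000 nM) in this test.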

Compound 4, half-maximal inhibitory concentration: 35100 nM
Compound 4: middle estimate off by 1.7-fold (0.23 log units), on the high side; low and high end bracket the measured number.
By their numbers in this assay, from the lowest: compounds 4, 2, 3 and 1 (each within the scatter of the next, the first and the last beyond it).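

In this assay, for the compounds shown here, chloro in place of acetyl gives a 1.9-fold lower number from compound 2 to compound 4 (0.27 log units; within the scatter), the first step here that isolates one place. At this aromatic carbon, para to a large group, the acetyl carbonyl and its hydrogen-bond acceptor can therefore go without a step beyond the scatter. Nothing available explains what this exchange does at this position. Going by these compounds, whether an amine, a carboxylic acid or a longer chain at this carbon would stay within the scatter remains open, as does the effect of moving chloro elsewhere on the ring.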